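Amide-linked analogues of the nitro-substituted benzyloxy anilide core

The source may report more compounds than this note shows. Statements on the series, on what has been measured and on what is new or still open speak of the compounds shown alone.

Measured so far:
compound 1, `CN(c1ccc([N+](=O)[O-])cc1OCc1ccc(Cl)cc1)S(C)(=O)=O`: in an assay on SK-BR-3 cells for inhibition of Aromatase (Homo sapiens) (on this read-out lower numbers stand for stronger inhibition and higher numbers for weaker inhibition), compound 1 gives 2400 nM.
compound 2, `Cc1ccc(C)c(COc2cc([N+](=O)[O-])ccc2NS(C)(=O)=O)c1`: in this assay compound 2 gives 370 nM.
compound 3, `O=C(Nc1ccc([N+](=O)[O-])cc1OCc1ccccc1)c1ccc([N+](=O)[O-])cc1`: in this assay compound 3 gives > 25000 nM.

Compound 3 stands apart from the other two in that its result is a limit rather than a number; its entry in this assay is the assay limit, (the limit of > 25000 nM in this assay, at which 1 of the 3 values shown sits). Among the compounds with values here, no single-point steps between measured compounds are available here, so nothing in the measured set directly calibrates the change that leads to compound 4.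

Compound 4, `O=C(Nc1ccc([N+](=O)[O-])cc1OCc1ccccc1)c1ccc2ccccc2c1`, differs from compound 3 by naphthalen-2-yl in place of 4-nitrophenyl on a carbonyl carbon. No direct evidence sets the size of this step, and with compound 3 sitting at the limit the starting point itself is uncertain. The expectation is a step from compound 3 to compound 4 of an at least 1.6-fold lower number from compound 3 to compound 4 (0.22 log units; that floor lies within the scatter), at most a modest gain and plausibly none beyond the scatter. Compound 4 is therefore estimated at 15000 nM in this assay, with a range from 3000 nM to 40000 nM.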

Compound 4, half-maximal inhibitory concentration: > 25000 nM
Compound 4 gave a limit, no number; the forecaster's own chance of this, stated with the estimate: 50%; middle value at least 1.6-fold (0.22 log units) from the limit.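

Within the data shown here, compound 3 and compound 4 both give a limit rather than a number in this assay, so no step between them can be read: the limit of > 25000 nM in this assay, at which 2 of the 4 values shown sit. The compounds shown leave open whether naphthalen-2-yl in place of 4-nitrophenyl on a carbonyl carbon shifts the value at all.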